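The source may hold more compounds than are shown below. What is called first, only, known or untested is meant among the compounds shown, and "the series" means these compounds.

Compound 1 `O=C(Nc1nc2ccccc2s1)c1cn(-c2ccccc2)nc1-c1ccccc1` anchors the series: in a functional assay on U-87MG ATCC cells for cytotoxicity against U-87 MG (Homo sapiens), read by MTT assay, with a stated time of 72 h (a higher number here means a weaker inhibitor, a lower number a stronger inhibitor), compound 1 gives 8960 nM. Compound 2 `Cc1ccc2nc(NC(=O)c3cn(-c4ccccc4)nc3-c3ccccc3)sc2c1` carries a methyl in place of hydrogen on an aromatic carbon; in this assay compound 2 gives 23200 nM, and the step reads a 2.6-fold higher number from compound 1 to compound 2 (0.41 log units; beyond the scatter). Compound 3 `O=C(Nc1nc2ccccc2s1)c1cn(-c2ccccc2)nc1-c1ccc(Cl)cc1` instead carries a chloro in place of hydrogen on an aromatic carbon; in this assay compound 3 gives 11500 nM, the step being a 1.3-fold higher number from compound 1 to compound 3 (0.11 log units; within the scatter). Among the three numbers compound 3 stands second highest, with compound 1 and compound 2 both within the scatter of it, so no order among the three is secure.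

Compound 4 `Cc1ccc2nc(NC(=O)c3cn(-c4ccccc4)nc3-c3ccc(Cl)cc3)sc2c1` combines both substituents; relative to compound 3 the change is methyl in place of hydrogen on an aromatic carbon. Within the data shown here, the only measured step that bears on it is the same methyl addition on the unsubstituted counterpart, a 2.6-fold higher number from compound 1 to compound 2 (0.41 log units; beyond the scatter), a modest rise lying beyond the scatter. If the two changes act independently, a rise of similar size is expected in this assay, the expected step being a 2.2-fold higher number from compound 3 to compound 4 (0.34 log units; beyond the scatter). Compound 4 is thus expected to give 25000 nM in this assay, with a range of 11000 nM to 55000 nM.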

Compound 4, half-maximal inhibitory concentration: 33200 nM
Beside the measured number, compound 4's estimate is 1.3-fold (0.12 log units) below it; the measured number falls inside the stated range.
By their numbers in this assay, from the lowest: compounds 1, 3, 2 and 4 (each within the scatter of the next, the first and the last beyond it).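

The methyl change now reads on a second core, with a 2.9-fold higher number from compound 3 to compound 4 (0.46 log units; beyond the scatter) in this assay, so 6-methyl-1,3-benzothiazol-2-yl in place of 1,3-benzothiazol-2-yl gives a higher number with or without the chloro group, by a matching amount: the same change on two cores in this assay, a 2.6-fold higher number (0.41 log units; beyond the scatter) from compound 1 to compound 2 and a 2.9-fold higher number (0.46 log units; beyond the scatter) from compound 3 to compound 4, 1.1-fold (0.05 log units) apart, within the scatter of two such steps. The chloro change stays within the scatter on the methylated core too, with a 1.4-fold higher number from compound 2 to compound 4 (0.16 log units; within the scatter), and it also matches across the two cores: the same change on two cores in this assay, a 1.3-fold higher number (0.11 log units; within the scatter) from compound 1 to compound 3 and a 1.4-fold higher number (0.16 log units; within the scatter) from compound 2 to compound 4, 1.1-fold (0.05 log units) apart, within the scatter of two such steps. Across these four compounds the two changes therefore behave as independent, and neither step depends on the other group being present.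

From the compounds shown here alone, whether an amine, a carboxylic acid or a longer chain such as ethyl at this position would also give a higher number remains open. Also open, going by these compounds, is whether any group here gives a lower number than hydrogen does.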